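Ether side-chain variation on the shared core

This account rests on a few compounds, and the source may have more. Where it says the series, first, only, none or still open, it means among the compounds named here.

compound 1 `CC(C)OCCOc1ccc(/C=C2\SC(O)=NC2=O)cc1Cl`: 2740 nM
compound 2 `O=C1NC(=O)/C(=C/c2ccc(OCc3ccc([N+](=O)[O-])cc3)c(Cl)c2)S1`: 930 nM
compound 3 `O=C1NC(=O)/C(=C/c2ccc(OCCOC3CCCCC3)c(Cl)c2)S1`: 20 nM

In an assay for inhibition of 15-hydroxyprostaglandin dehydrogenase [NAD(+)] (Homo sapiens), read by fluorescence and spectrophotometry (a higher number here means a weaker inhibitor, a lower number a stronger inhibitor), compound 3 gives 20 nM, the lowest of the three numbers. Compound 2 gives 930 nM and compound 1 gives 2740 nM; both gaps to compound 3 lie beyond the scatter, so compound 3 stands as the strongest inhibitor of the set.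

Compound 4 `O=C1NC(=O)/C(=C/c2ccc(OCC3CC4CCC3C4)c(Cl)c2)S1` differs from compound 3 by a group of 7 heavy atoms (7 carbon; 2 five-membered non-aromatic rings of carbon only) in place of a group of 8 heavy atoms (7 carbon, 1 oxygen; one six-membered non-aromatic ring of carbon only), on a saturated chain carbon bound to an oxygen on an aromatic ring. For the measured compounds named here, no pair of measured compounds shows this change, so no measured step guides it. The number for compound 4 in this assay is expected to rise beyond the scatter, the step of a 4.0-fold higher number from compound 3 to compound 4 (0.60 log units; beyond the scatter) being the estimate. For compound 4 the estimated value is 80 nM, within 20 nM to 400 nM.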

Compound 4, half-maximal inhibitory concentration: 165 nM
For compound 4 the middle estimate is 2.1-fold (0.31 log units) below the measured one; the range from low to high includes it.
By their numbers in this assay, from the lowest: compound 3; then compound 4; then compound 2; then compound 1.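

In this assay, placing a group with 2 five-membered non-aromatic rings of carbon only where compound 3 has (cyclohexyloxy)methyl, on a saturated chain carbon bound to an oxygen on an aromatic ring, gives an 8.3-fold higher number from compound 3 to compound 4 (0.92 log units; beyond the scatter). For the compounds shown here, this is the only single-place step, and it shows that this position responds to the change, with (cyclohexyloxy)methyl the stronger of the two groups. Nothing at hand accounts for the step. The ether oxygen and the ring change remain unseparated here; a cyclohexylethyl group or a morpholine ring at this position would be informative.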